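Cyclopropyl for ethyl on the aryl ring of compound 1

The source may hold more compounds than are shown below. What is called first, only, known or untested is meant among the compounds shown, and "the series" means these compounds.

Compound 1 `CCc1ccccc1-c1cc(C(=O)N[C@@H](CCN2CCCCC2)CC(=O)NC2CCC2)nn1C1CCCC1`, an ADME assay on microsomes from liver (Rattus norvegicus, strain Sprague-Dawley) for metabolic stability, read by LC-MS, using NADPH, with a stated time of 30 min, tested at 1 uM; on this read-out higher numbers stand for a more stable compound and lower numbers for a less stable compound: 76.5%
Compound 2 `O=C(C[C@H](CCN1CCCCC1)NC(=O)c1cc(-c2cscn2)n(C2CCCC2)n1)NC1CCC1`, this assay: "nd" (no result reported)

Among the compounds with values here, compound 1 is the only compound with a number in this assay; compound 2 carries no result. Compound 3 `O=C(C[C@H](CCN1CCCCC1)NC(=O)c1cc(-c2ccccc2C2CC2)n(C2CCCC2)n1)NC1CCC1` has not yet been measured. It differs from compound 1 in one place: cyclopropyl in place of ethyl on an aromatic carbon. Within the data shown here, no measured pair shows this change, so nothing sets its size. The step is expected to stay within the scatter, with no direction beyond it, so the estimated step is a number 1.5 percentage points higher from compound 1 to compound 3 (within the scatter). Compound 3 is therefore expected to give 78%, between 60% and 92%.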

Compound 3, percent of the compound remaining: 70.1%
Estimate against measurement, compound 3: 7.9 percentage points above; measured number inside the range.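

In this assay, cyclopropyl in place of ethyl on the aromatic carbon gives a number 6.4 percentage points lower from compound 1 to compound 3 (within the scatter). Within the data shown here, this is the first reading at this position, and it shows that a three-membered ring of carbon can replace the ethyl group here without a step beyond the scatter. No measurement shown bears on what lies behind this number. The compounds shown leave open whether a methoxy group, a trifluoromethyl group or an amine on this aromatic carbon would stay as close to compound 1, and what a longer chain would do there.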